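This account rests on a few compounds, and the source may have more. Where it says the series, first, only, none or still open, it means among the compounds named here.

Compound 3 `CCCCc1cnc(CCc2ccc(-c3ccccc3C(=O)O)cc2)[nH]1` gives 2710 nM in an in vitro functional assay on cells for agonist activity at Bombesin receptor subtype-3 (Homo sapiens), read by luminescence and calcium flux (on this read-out lower numbers stand for an effect already at smaller amounts and higher numbers for an effect only at larger amounts of compound), and stands second highest of the three numbers, with compound 1 `Cc1cccc(Cc2cnc(CCc3ccc(-c4ccccc4C(=O)O)cc3)[nH]2)c1` at 4310 nM nearest it and compound 2 `CC(C)(C)Cc1cnc(CCc2ccc(-c3ccccc3C(=O)O)cc2)[nH]1` at 106 nM furthest. Compound 4 `CC(C)(C)c1cnc(CCc2ccc(-c3ccccc3C(=O)O)cc2)[nH]1` differs from compound 3 by tert-butyl in place of butyl on an aromatic carbon. Going by the values given here, the measured steps that bear on this are a 26-fold higher number from compound 2 to compound 3 (1.41 log units; beyond the scatter) and a 41-fold lower number from compound 1 to compound 2 (1.61 log units; beyond the scatter), both large and both favouring the branched group on the saturated chain carbon; no measured pair shows a group placed directly on the aromatic carbon, so the shortening in compound 4 is untested. The step of a 5.4-fold lower number from compound 3 to compound 4 (0.73 log units; beyond the scatter) is therefore expected, towards a lower number but less certain than the measured ones. For compound 4 a value of 500 nM is estimated, within 100 nM to 2500 nM.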

Compound 4, half-maximal effective concentration: 4330 nM
Compound 4: the middle estimate sits 8.7-fold (0.94 log units) below what was measured; measured number above the stated range.
By their numbers in this assay, from the lowest: compound 2; then compounds 3, 1 and 4 (each within the scatter of the next).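

In this assay, going by these compounds alone, tert-butyl on the aromatic carbon does not keep what neopentyl gives, with a 41-fold higher number from compound 2 to compound 4 (1.61 log units; beyond the scatter) as the one large step at this position. Against butyl the exchange of joined atoms leaves no readable difference, with a 1.6-fold higher number from compound 3 to compound 4 (0.20 log units; within the scatter) and the same holds against 3-methylbenzyl, with a 1.0-fold higher number from compound 1 to compound 4 (0.00 log units; within the scatter) so branching alone does not set the number, and compound 2 alone stands apart. From the compounds shown here alone, whether isopropyl or cyclohexylmethyl at this carbon would behave like neopentyl stays open. Nothing available gives a reason for these numbers.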